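Working notes: from compound 3 to compound 4

The source may report more compounds than this note shows. Statements on the series, on what has been measured and on what is new or still open speak of the compounds shown alone.

Measured so far in a functional assay on A549/CDDP cells (Homo sapiens) for antiproliferative activity, read by MTT assay, with a stated time of 72 h (a lower number here means a stronger inhibitor, a higher number a weaker inhibitor), with these values

- compound 1 `Cc1nc(C)c(/C=C/C(=O)/C=C/c2cccc(O)c2)nc1C` gives 3700 nM
- compound 2 `COc1ccc(/C=C/C(=O)/C=C/c2nc(C)c(C)nc2C)cc1` gives 3610 nM
- compound 3 `Cc1nc(C)c(/C=C/C(=O)/C=C/c2ccccc2)nc1C` gives 11900 nM

Of these three, compound 3 stands highest in this assay and is the weakest, with both of its steps to the others beyond the scatter. Compound 4 `Cc1nc(C)c(/C=C/C(=O)/C=C/c2ccc(F)cc2)nc1C` has not yet been measured. The change is fluoro in place of hydrogen on an aromatic carbon and amounts to fluoro in place of hydrogen on an aromatic carbon, para to a large group. Among the measured compounds shown here, two measured steps bear on it, each modest and each with hydrogen replacing a group on an aromatic carbon. Hydroxy leaves in a 3.2-fold higher number from compound 1 to compound 3 (0.51 log units; beyond the scatter) and methoxy leaves in a 3.3-fold higher number from compound 2 to compound 3 (0.52 log units; beyond the scatter) as the second case. Neither step involves fluoro, so they guide direction only loosely. Read in reverse, they point to a lower number when a group enters. The estimated step of a 2.2-fold lower number from compound 3 to compound 4 (0.34 log units; beyond the scatter) is expected to be somewhat smaller than those two. For compound 4 the estimate is 5500 nM with an expected range from 2500 nM to 12000 nM on this reading.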

Compound 4, half-maximal inhibitory concentration: 7440 nM
For compound 4 the middle estimate is 1.4-fold (0.13 log units) below the measured one; the measured number falls inside the stated range.
By their numbers in this assay, from the lowest: compounds 2, 1, 4 and 3 (each within the scatter of the next, the first and the last beyond it).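

In this assay, among the compounds shown here, the change from phenyl to 4-fluorophenyl gives a 1.6-fold lower number from compound 3 to compound 4 (0.20 log units; within the scatter), so fluoro at this place is not told apart from hydrogen, whereas the earlier steps from hydroxy and methoxy to hydrogen were beyond the scatter. The identity of the group does register, with fluoro in place of methoxy giving a 2.1-fold higher number from compound 2 to compound 4 (0.31 log units; beyond the scatter), which shows that having a group on this aromatic carbon does not alone settle the number. The step from 3-hydroxyphenyl to 4-fluorophenyl, a 2.0-fold higher number from compound 1 to compound 4 (0.30 log units; within the scatter), separates neither, and no measurement available here accounts for any of these steps.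

On these data alone, whether an amine or a carboxylic acid at this place would move the number beyond the scatter from compound 3 remains open. Also open, as far as these compounds go, is whether ethoxy, a longer chain than methoxy, would keep the gap seen against fluoro.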